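One Group Exchanged on a Carbonyl Carbon

This account rests on a few compounds, and the source may have more. Where it says the series, first, only, none or still open, it means among the compounds named here.

In a physicochemical assay for solubility, at pH 6.8 (on this read-out lower numbers stand for lower solubility and higher numbers for higher solubility), compound 1 (`O=C(c1c[nH]c(=O)c2ccccc12)N1CCN(C(=O)c2ccc(Br)cc2)[C@@H](c2ccc(Cl)cc2)C1`) gives 11 ug/mL and compound 2 (`O=C(c1cc(-c2cccc(C(F)(F)F)c2)c(=O)n(-c2ccccc2)c1)N1CCN(C(=O)c2ccc(Br)cn2)[C@@H](c2ccc(Cl)cc2)C1`) gives 5.9 ug/mL. These two values lie within the usual scatter of each other, so compound 1 does not stand apart from compound 2 on these numbers.

Compound 3 (`O=C(c1cncc2ccccc12)N1CCN(C(=O)c2ccc(Br)cc2)[C@@H](c2ccc(Cl)cc2)C1`) keeps the rest of compound 1 and differs in a single group: a group of 10 heavy atoms (9 carbon, 1 nitrogen; one six-membered aromatic ring of carbon only, one six-membered aromatic ring with 1 hetero atom) in place of a group of 11 heavy atoms (9 carbon, 1 nitrogen, 1 oxygen; one six-membered aromatic ring of carbon only, one six-membered aromatic ring with 1 hetero atom), on a carbonyl carbon. The isoquinolin-4-yl group enters on a carbonyl carbon whose other neighbours are: amide-type nitrogen in a ring.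

Within the data shown here, no measured pair shows this exchange alone, and compound 1 and compound 2 differ in more than one place, so the data offer no direct guide to its size. The expectation in this assay is therefore a cautious one: a small upward step, near the edge of the scatter. The expected change is a 1.6-fold higher number from compound 1 to compound 3 (0.21 log units; within the scatter). For compound 3 the estimated value is 18 ug/mL, with an expected range from 6 ug/mL to 50 ug/mL.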

Compound 3, solubility: 5.1 ug/mL
Compound 3: the middle estimate sits 3.5-fold (0.55 log units) above what was measured; the whole stated range lies above it.
By their numbers in this assay, from the lowest: compounds 3, 2 and 1 (each within the scatter of the next, the first and the last beyond it).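

Among these compounds, the exchange on the carbonyl carbon supplies the first step that can be read in one place: in this assay, isoquinolin-4-yl in place of the group carried by compound 1 gives a 2.2-fold lower number from compound 1 to compound 3 (0.33 log units; beyond the scatter). The two earlier compounds could not show this, as they differ in more than one place and their values lie within the scatter of each other. The step is modest, but it shows that this position is not silent on this read-out, and that the group that leaves, with its oxygen, its double bond outside the aromatic rings and its hydrogen-bond donor, cannot be exchanged for isoquinolin-4-yl without a readable change. No measurement at hand speaks to what lies behind this step.

The compounds shown leave open whether the oxygen and the hydrogen-bond donor matter together or whether either one alone carries the step, and whether the same exchange would give a similar step with other groups elsewhere on the shared core. They also leave open where a group bearing an amine or a carboxylic acid, on this carbonyl carbon, would fall in this assay relative to compound 1.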